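The compounds below may be only part of what the source reports. "The series", "measured", "known", "first", "only" and "open" are said of these compounds alone.

In a physicochemical assay for lipophilicity (on this read-out lower numbers stand for lower lipophilicity and higher numbers for higher lipophilicity), compound 1 `CCOc1ccccc1C1=NC(c2ccccc2)CO1` gives 4.22. Among the three compounds measured so far, compound 3 `Clc1cccc(C2=NC(c3ccccc3)CO2)c1Cl` gives 4.28, which lies within the usual scatter of compound 1, so the two cannot be told apart. Compound 2 `Fc1cccc(Cl)c1-c1ncco1` gives 1.89, lower than compound 1 by a gap well beyond the scatter.

Compound 4 `CSc1ccccc1C1=NC(c2ccccc2)CO1` has not yet been measured. It carries methylsulfanyl in place of ethoxy on an aromatic carbon, ortho to a large group: methylsulfanyl in place of ethoxy on an aromatic carbon. For the measured compounds named here, no measured pair shows this exchange, so any expectation here is tentative. Going by the values given here, the only guide is that, while sharing the core of compound 1 but substituted differently, compound 3 still gives 4.28. A small upward step in this assay, no larger than the scatter, therefore seems most likely. The expected change is a number 0.13 log units higher from compound 1 to compound 4 (within the scatter). Compound 4 is estimated at 4.35, with an expected range from 3.95 to 4.75.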

Compound 4, partition coefficient: 3.5
Compound 4: the middle estimate sits 0.85 log units above what was measured; the measured number lies below the stated range.
By their numbers in this assay, from the lowest: compound 2; then compound 4; then compounds 1 and 3 (each within the scatter of the next).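

Exchanging ethoxy for methylsulfanyl on an aromatic carbon, ortho to a large group, gives in this assay a number 0.72 log units lower from compound 1 to compound 4 (beyond the scatter). For the compounds shown here, this is the first pair in the set that differs in one place, so it shows that this position is not silent: with the rest of compound 1 unchanged, a change of substituent here alone moves the read-out by more than the scatter. The exchange replaces 3 heavy atoms with 2 and swaps oxygen for sulfur, so this single step combines a change in size with a change of atom.

Methoxy at the same carbon would help separate the two, while an amine there would test a quite different kind of group. Whether the step carries over to other compounds remains open, and nothing available here explains its direction or size.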